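The source may report more compounds than this note shows. Statements on the series, on what has been measured and on what is new or still open speak of the compounds shown alone.

Measured so far in an assay on CHO cells for agonist activity at Neuronal acetylcholine receptor; alpha3/beta4 (Homo sapiens), read by FLIPR and calcium flux; on this read-out higher numbers stand for larger maximal responses and lower numbers for smaller maximal responses:
compound 1 `C[C@H]1C[C@H]1C(=O)N1CC2CNCC2C1`, 110%
compound 2 `C[C@H]1C[C@@H]1C(=O)N1CC2CNCC2C1`, 26%
compound 3 `CC(=O)N1CC2CNCC2C1`, 36%

Compound 3 sits second of the three numbers; the gap to compound 2 lies within the scatter, while compound 1 stands far higher. Compound 4 `CCC(=O)N1CC2CNCC2C1` carries methyl in place of hydrogen on a saturated chain carbon bound to a carbonyl carbon. Going by the values given here, no measured step matches this change directly. The nearest are a number 74 percentage points lower from compound 1 to compound 3 (beyond the scatter) and a number 10 percentage points higher from compound 2 to compound 3 (within the scatter), both swapping the methyl for a 2-methylcyclopropyl on the carbonyl carbon; the first is large, the second within the scatter, so a larger acyl group can move the response either way. Extending acetyl to propanoyl is a smaller change than either, and the expected step is a number 9 percentage points higher from compound 3 to compound 4 (within the scatter), modest and upward. Compound 4 is expected to give 45% in this assay, between 25% and 75%.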

Compound 4, largest response reached (Emax), in percent of the reference or control that the assay uses: 130%
Beside the measured number, compound 4's estimate is 85 percentage points below it, and the stated range ends below it.
By their numbers in this assay, from the lowest: compounds 2 and 3 (each within the scatter of the next); then compound 1; then compound 4.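

Going by these compounds alone, a single methyl on the saturated chain carbon bound to a carbonyl carbon gives a number 94 percentage points higher from compound 3 to compound 4 (beyond the scatter) and so shows that this position responds strongly to a very small change, which the earlier compounds could not show. Propanoyl also gives a number 104 percentage points higher from compound 2 to compound 4 (beyond the scatter) and a number 20 percentage points higher from compound 1 to compound 4 (beyond the scatter), so a high response in this set of amides does not require the 2-methylcyclopropyl group. No available evidence bears on why the added methyl has so large an effect.

Going by these compounds, whether the response holds, rises or falls with a longer chain such as butanoyl or a branched one such as isobutyryl remains open. On these data alone, the response with an unsubstituted cyclopropyl on the carbonyl carbon is also open.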